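Replacing 4-methylpiperazin-1-yl with cyclohexyl in a cytotoxic series

A few compounds are considered here, and "the series" means these few. Any claim that something is new, unique, unknown or untested is made for them only; others in the source may bear on it.

Of the compounds shown here, three sharing one core have been measured in a functional assay on MIA PaCa-2 cells (Homo sapiens) for cytotoxicity, read by MTT assay, with a stated time of 72 h; on this read-out higher numbers stand for weaker inhibition and lower numbers for stronger inhibition. Compound 1 `O=C1C(Nc2ccc(-c3ccc(Cl)cc3)cc2)=CC(=O)c2ncncc21` gives 9700 nM, and compound 2 `O=C1C(Nc2cccc(-c3ccccc3)c2)=CC(=O)c2ncncc21` gives 2400 nM. Compound 3 `CN1CCN(c2ccc(NC3=CC(=O)c4ncncc4C3=O)cc2)CC1` gives 530 nM, the lowest of the three numbers, and both other compounds lie beyond the usual scatter from it. The next compound to be tested is compound 4 `O=C1C(Nc2ccc(C3CCCCC3)cc2)=CC(=O)c2ncncc21`, which carries cyclohexyl in place of 4-methylpiperazin-1-yl on an aromatic carbon.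

For the measured compounds named here, one measured step bears directly on this change. Replacing 4-chlorophenyl with 4-methylpiperazin-1-yl gave a large drop, an 18-fold lower number from compound 1 to compound 3 (1.26 log units; beyond the scatter). Compound 4 gives up that same group for a ring of carbon only, so the step is expected to run the other way, towards a higher number. Going by the values given here, compound 2, which also lacks the group, stands at 2400 nM, and this suggests a rise somewhat smaller than the one seen for compound 1. Only compound 3 carries the group, however, so this evidence is thin. The expected change in this assay is therefore a clear rise beyond the scatter, a 7.5-fold higher number from compound 3 to compound 4 (0.88 log units; beyond the scatter). Compound 4 is estimated at 4000 nM, with an expected range of 1500 nM to 11000 nM.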

Compound 4, half-maximal inhibitory concentration: 1200 nM
Estimate against measurement, compound 4: 3.3-fold (0.52 log units) above, and the stated range ends above it.
By their numbers in this assay, from the lowest: compound 3; then compounds 4 and 2 (each within the scatter of the next); then compound 1.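

In this assay, the change from 4-methylpiperazin-1-yl to cyclohexyl gives a 2.3-fold higher number from compound 3 to compound 4 (0.35 log units; beyond the scatter) and so remains a modest step, which shows that a six-membered ring of carbon only, with no hydrogen-bond acceptors, can stand at this aromatic carbon with a limited loss. The step of an 8.1-fold lower number from compound 1 to compound 4 (0.91 log units; beyond the scatter) is also new, and it shows that the large gain seen earlier at this position does not require 4-methylpiperazin-1-yl: most of that gain is also reached with cyclohexyl, although compound 3 keeps a lower number than compound 4 beyond the scatter. Nothing at hand explains why these three groups rank as they do at this position.

The compounds shown leave open whether either nitrogen of 4-methylpiperazin-1-yl accounts for the remaining difference between compound 3 and compound 4, which a morpholin-4-yl or piperidin-1-yl group at the same place would help to separate. They also leave open how much of the weak result for compound 1 belongs to the chlorine of 4-chlorophenyl rather than to its ring, a question that a plain phenyl at this place would address.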